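This account rests on a few compounds, and the source may have more. Where it says the series, first, only, none or still open, it means among the compounds named here.

Measured compounds:
compound 1 `CC(C)(C)n1ncc(OCc2nnc(-c3cccc(F)c3)o2)c(Cl)c1=O` — 7100 nM
compound 2 `CC(C)(C)n1ncc(OCc2nnc(-c3ccc(C(F)(F)F)cc3)o2)c(Cl)c1=O` — 33800 nM

Both were run in a functional assay on the whole organism for inhibition, with Mythimna separata as the target, with a stated time of 5 days; on this read-out higher numbers stand for an effect only at larger amounts of compound and lower numbers for an effect already at smaller amounts. On that read-out compound 1 gives 7100 nM and compound 2 gives 33800 nM. Compound 2 thus stands at the highest of the two numbers, and the gap to compound 1, the nearest, lies beyond the usual scatter. Within the data shown here, no pair of measured compounds differs in a single place, so nothing in the measured set speaks directly to a change of one group alone; compound 1 against compound 2 is read only as what the two values show.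

Compound 3 `COc1ccc(-c2nnc(COc3cnn(C(C)(C)C)c(=O)c3Cl)o2)cc1` is the next to be measured. It differs from compound 2 in one place: methoxy in place of trifluoromethyl on an aromatic carbon. Among the measured compounds shown here, no measured step carries this change, so the direction can only be guessed from the two values at hand. The expectation for compound 3 is a modest move toward a lower number, a 2.3-fold lower number from compound 2 to compound 3 (0.35 log units; beyond the scatter), roughly at the edge of the scatter rather than clearly beyond it. Compound 3 is therefore estimated at 15000 nM in this assay, with a range from 4000 nM to 60000 nM.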

Compound 3, half-maximal effective concentration: 17700 nM
Compound 3: the middle estimate sits 1.2-fold (0.07 log units) below what was measured; the range from low to high includes it.
By their numbers in this assay, from the lowest: compound 1; then compounds 3 and 2 (each within the scatter of the next).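

At this position, on an aromatic carbon para to a large group, methoxy in place of trifluoromethyl gives a 1.9-fold lower number from compound 2 to compound 3 (0.28 log units; within the scatter) in this assay, so two groups that differ in size and in hydrogen-bond acceptor count cannot be told apart on this read-out. The change from the 3-fluorophenyl of compound 1 gives a 2.5-fold higher number from compound 1 to compound 3 (0.40 log units; beyond the scatter), which is a modest step and leaves compound 1 with the lowest number of the three, but it alters both the group and its place on the ring, so neither can be credited alone. Nothing measured here bears on why the numbers fall as they do.

Still open, on these data alone, is whether the higher numbers of compound 2 and compound 3 go with the place of the group or with the group itself, a question that methoxy or trifluoromethyl on the carbon bearing fluorine in compound 1 would address. Also open, as far as these compounds go, is how an amine, a carboxylic acid, a nitrile or a longer alkoxy chain would read at this position, and whether the shared core tolerates any change at all.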